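Series notes: chloro for methoxy in compound 2

A few compounds are considered here, and "the series" means these few. Any claim that something is new, unique, unknown or untested is made for them only; others in the source may bear on it.

In a functional assay on SK-N-MC cells (Homo sapiens) for cytotoxicity, read by MTT assay (a higher number here means a weaker inhibitor, a lower number a stronger inhibitor), compound 2 `COc1cccc(/C=C2\CCC/C(=C\c3cccc([N+](=O)[O-])c3)C2=O)c1` gives 4.94 ug/mL, the lowest number of the three measured. Compound 3 `COc1cccc(/C=C2\CCC/C(=C\c3cccc([N+](=O)[O-])c3)C2=O)c1OC` gives 10.1 ug/mL, and compound 1 `COc1ccc(/C=C2\CCC/C(=C\c3ccccc3[N+](=O)[O-])C2=O)cc1` gives 75 ug/mL. Among the compounds with values here, the only single-point step, a 2.0-fold higher number from compound 2 to compound 3 (0.31 log units; beyond the scatter), came from a methoxy added to an aromatic carbon. Compound 4 `O=C1/C(=C/c2cccc(Cl)c2)CCC/C1=C\c1cccc([N+](=O)[O-])c1` differs from compound 2 by chloro in place of methoxy on an aromatic carbon. Within the data shown here, no measured step swaps one substituent for another on this ring, and the one step that bears on substituent changes here, a 2.0-fold higher number from compound 2 to compound 3 (0.31 log units; beyond the scatter), was modest, so for compound 4 the expected step of a 1.1-fold higher number from compound 2 to compound 4 (0.05 log units; within the scatter) is small and may not exceed the scatter. The estimate for compound 4 is 5.5 ug/mL, with a range from 2.2 ug/mL to 14 ug/mL.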

Compound 4, half-maximal inhibitory concentration: 4.15 ug/mL
Compound 4: the middle estimate sits 1.3-fold (0.12 log units) above what was measured; low and high end bracket the measured number.
By their numbers in this assay, from the lowest: compounds 4 and 2 (each within the scatter of the next); then compound 3; then compound 1.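

Earlier data showed only a methoxy added to the ring. Within the data shown here, this is the first exchange of one substituent for another, on an aromatic carbon meta to a large group. In this assay, going from 3-methoxyphenyl to 3-chlorophenyl gives a 1.2-fold lower number from compound 2 to compound 4 (0.08 log units; within the scatter) and so leaves the number in place, showing that the methoxy is not required here and that chloro can stand in for it. Nothing on hand accounts for this match.

As far as these compounds go, whether an amine or a carboxylic acid on this carbon would also leave the number in place remains open. So does whether chloro matches methoxy at other ring positions.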